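The compounds below may be only part of what the source reports. "The series", "measured", "known", "first", "only" and "open" are said of these compounds alone.

Measured compounds in this study:

Compound 1, `Cc1ncnc2c1c(I)cn2[C@@H]1O[C@H](CO)[C@@H](O)[C@H]1O` — in a functional assay on HL-60 cells (Homo sapiens) for antiproliferative activity, read by XTT assay, with a stated time of 72 h (a lower number here means a stronger inhibitor, a higher number a weaker inhibitor), compound 1 gives 2650 nM.
Compound 2, `C#Cc1cn([C@@H]2O[C@H](CO)[C@@H](O)[C@H]2O)c2ncnc(C)c12` — compound 2 gives 1110 nM.
Compound 3, `C#Cc1cn([C@@H]2O[C@H](CO)[C@@H](O)[C@H]2O)c2nc(C)nc(N)c12` — compound 3 gives > 20000 nM.

Compound 1 and compound 2 share a core and differ in one group: iodo in place of ethynyl on an aromatic carbon. Between the two, the measurement shows a 2.4-fold higher number from compound 2 to compound 1 (0.38 log units; beyond the scatter). Compound 3 carries a different core; how the cores of compound 2 and compound 3 differ is not broken down here. For compound 3 the assay gave only a limit and no number, (the limit of > 20000 nM in this assay, at which 1 of the 3 values shown sits).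

Compound 4, `Cc1nc(N)c2c(I)cn([C@@H]3O[C@H](CO)[C@@H](O)[C@H]3O)c2n1`, has not yet been measured in this assay. Compound 4 differs from compound 3 by iodo in place of ethynyl on an aromatic carbon. Among the compounds with values here, the place of the change is described in the same words for both pairs, so the change from compound 3 to compound 4 is the same change as the one from compound 2 to compound 1. Within the data shown here, the step from compound 3 to compound 4 is expected to be a step that the limit leaves unreadable from compound 3 to compound 4, a size that rests on the single measured example, a 2.4-fold higher number from compound 2 to compound 1 (0.38 log units; beyond the scatter), which made the number higher. Compound 3 already sits at a limit, so compound 4 is expected to give only a limit as well. As a number, compound 4 is estimated at 45000 nM, within a range from 15000 nM to 150000 nM.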

Compound 4, half-maximal inhibitory concentration: 2050 nM
The estimate for compound 4 lay 22-fold (1.34 log units) above the measured number; measured number below the stated range.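

In this assay, putting iodo in place of ethynyl does not carry over from one core to another as a fixed step, and the two examples point in opposite directions: the same change on two cores in this assay, a 2.4-fold higher number (0.38 log units; beyond the scatter) from compound 2 to compound 1 and an at least 9.7-fold lower number (0.98 log units; beyond the scatter) from compound 3 to compound 4, at least 23-fold (1.36 log units) apart, beyond the scatter of two such steps
The new result is an at least 9.7-fold lower number from compound 3 to compound 4 (0.98 log units; beyond the scatter), so on this core the iodo compound, compound 4, is the stronger inhibitor, whereas on the other core the iodo compound, compound 1, is the weaker one. Compound 3 gives > 20000 nM, which is a limit of the assay and not a number, so the size of this step is known only as a minimum; with just one pair on each core, the data show that the outcome of the change differs between these two cores but not what in the cores is responsible.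

The compounds shown leave open which part of the difference between the two cores goes with the reversal, and a pair differing in a single place on the core would be needed to separate this. They also leave open how bromo, a nitrile or a phenyl ring on the same aromatic carbon would compare with ethynyl and iodo on each core.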